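Trifluoromethyl for methyl on the core of compound 1

This account rests on a few compounds, and the source may have more. Where it says the series, first, only, none or still open, it means among the compounds named here.

Compound 1, `COc1ccc2nc(C)cc(OCC(=O)Nc3cc(C)cc(C)c3)c2c1`: in a toxicity assay on HepG2 cells (Homo sapiens) for inhibition, read by CellTiter-Glo, with a stated time of 48 h (on this read-out lower numbers stand for stronger inhibition and higher numbers for weaker inhibition), compound 1 gives 20000 nM.
Compound 2, `Cc1cc(C)cc(NC(=O)COc2cc(C)nc3ccc(OC(F)(F)F)cc23)c1`: compound 2 gives only the limit > 100000 nM.
Compound 3, `Cc1cc(C)cc(NC(=O)COc2cc(C)nc3ccc(OCc4ccccc4)cc23)c1`: compound 3 gives only the limit > 100000 nM.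

Going by the values given here, compound 1 thus holds the only number among the three. Compounds 2 and 3 both sit at the limit of > 100000 nM in this assay, at which 2 of the 3 values shown sit. Compound 4, `COc1ccc2nc(C(F)(F)F)cc(OCC(=O)Nc3cc(C)cc(C)c3)c2c1`, differs from compound 1 by trifluoromethyl in place of methyl on an aromatic carbon. The nearest measured step is an at least 5.0-fold higher number from compound 1 to compound 2 (0.69 log units; beyond the scatter), where trifluoromethyl also enters, there on an oxygen on an aromatic ring; an at least 5.0-fold higher number from compound 1 to compound 3 (0.69 log units; beyond the scatter) runs the same way, and a step that the two limits leave unreadable from compound 2 to compound 3. From these a higher number is expected for compound 4 in this assay, a 2.5-fold higher number from compound 1 to compound 4 (0.40 log units; beyond the scatter), with a real chance of only a limit. Compound 4 is estimated at 50000 nM, ranging from 15000 nM to 150000 nM.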

Compound 4, half-maximal inhibitory concentration: > 100000 nM
Compound 4: no number, only a limit (the forecaster's own chance of this, stated with the estimate: 45%); middle value at least 2.0-fold (0.30 log units) from the limit.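

On the aromatic carbon next to the ring nitrogen, trifluoromethyl in place of methyl gives an at least 5.0-fold higher number from compound 1 to compound 4 (0.69 log units; beyond the scatter) in this assay. The shift to a higher number is therefore not confined to changes on the oxygen on the aromatic ring, as seen with compounds 2 and 3. Compound 4 gives only a limit, so the true size of the step stays unknown, and compound 1 remains the only compound with a number: the limit of > 100000 nM in this assay, at which 3 of the 4 values shown sit.

As far as these compounds go, whether an amine or an ethyl group on this aromatic carbon would give a number rather than a limit remains open.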